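Sulfone in place of sulfoxide in the chloro compound

A few compounds are considered here, and "the series" means these few. Any claim that something is new, unique, unknown or untested is made for them only; others in the source may bear on it.

Compound 1 `C[S+]([O-])C[C@H]1O[C@@H](n2cnc3c(N)nc(F)nc32)[C@H](O)[C@@H]1O`: 13000 nM
Compound 2 `C[S+]([O-])C[C@H]1O[C@@H](n2cnc3c(N)nc(Cl)nc32)[C@H](O)[C@@H]1O`: 259000 nM

For the measured compounds named here, in an ADME assay on L6 cells (Rattus norvegicus) for inhibition, read by resazurin assay, with a stated time of 72 h (a higher number here means a weaker inhibitor, a lower number a stronger inhibitor), compound 2 gives the higher of the two numbers, 259000 nM, and compound 1 is its only neighbour. Going by the values given here, the one measured step is a 20-fold higher number from compound 1 to compound 2 (1.30 log units; beyond the scatter), with chloro in place of fluoro on an aromatic carbon.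

Compound 3 `CS(=O)(=O)C[C@H]1O[C@@H](n2cnc3c(N)nc(Cl)nc32)[C@H](O)[C@@H]1O` keeps the chloro of compound 2 and carries methylsulfonyl on a saturated chain carbon bound to a saturated ring carbon: a group of 4 heavy atoms (1 carbon, 2 oxygen, 1 sulfur; no ring) in place of a group of 3 heavy atoms (1 carbon, 1 oxygen, 1 sulfur; no ring), on a saturated chain carbon bound to a saturated ring carbon.

The large measured step concerns the halogen only. Among the compounds with values here, no measured step touches the group that changes here, so the series gives no direct guide to size or direction. With no evidence for a shift, no step beyond the scatter is expected in this assay. Within the data shown here, the range is kept wide, since the one step available, a 20-fold higher number from compound 1 to compound 2 (1.30 log units; beyond the scatter), shows that a single change can move this series a long way.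

The estimated step is a 1.3-fold lower number from compound 2 to compound 3 (0.11 log units; within the scatter). For compound 3 the expected value is 200000 nM, with an estimated range of 60000 nM to 450000 nM.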

Compound 3, half-maximal inhibitory concentration: 156000 nM
Beside the measured number, compound 3's estimate is 1.3-fold (0.11 log units) above it; low and high end bracket the measured number.
By their numbers in this assay, from the lowest: compound 1; then compounds 3 and 2 (each within the scatter of the next).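

For the compounds shown here, on the saturated chain carbon bound to a saturated ring carbon, methylsulfonyl in place of the sulfoxide group gives a 1.7-fold lower number from compound 2 to compound 3 (0.22 log units; within the scatter) in this assay, so this is the first measured step at this place, and it does not separate compound 2 from compound 3. Going by these compounds alone, the entering group counts one more heavy atom and 2 hydrogen-bond acceptors against 1, yet with chloro held constant this change stays within the scatter, unlike the halogen change, a 20-fold higher number from compound 1 to compound 2 (1.30 log units; beyond the scatter), which remains the only step beyond the scatter so far. No measurement on hand bears on the reason for this result.

On these data alone, it remains open whether methylsulfonyl would also leave the number within the scatter with the fluoro of compound 1, since this single step was read with chloro only. As far as these compounds go, it is also open whether a more different group on that saturated chain carbon, such as a carboxylic acid, an amine or a longer chain, would move the number in this assay beyond the scatter.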